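From 4-methoxybenzyl to 2-methylbenzyl in compound 3

This account rests on a few compounds, and the source may have more. Where it says the series, first, only, none or still open, it means among the compounds named here.

Measured so far in a functional assay, read by spectrophotometry, with a stated time of 30 min; on this read-out lower numbers stand for stronger inhibition and higher numbers for weaker inhibition
- compound 1 `CC(C)(C)c1cc(/C=C/C(=O)NCCC2CCN(Cc3ccccc3)CC2)cc(C(C)(C)C)c1O` gives 81700 nM
- compound 2 `COc1ccc(CN2CCC(CCNC(=O)/C=C/c3cc(C(C)(C)C)c(O)c(C(C)(C)C)c3)CC2)cc1` gives 61200 nM

Going by the values given here, compound 2 gives 61200 nM and lies within the scatter of compound 1, the only other measured compound. Compound 3 `Cc1ccccc1CN1CCC(CCNC(=O)/C=C/c2cc(C(C)(C)C)c(O)c(C(C)(C)C)c2)CC1` is reached by one change 2-methylphenyl in place of 4-methoxyphenyl on a saturated chain carbon bound to an amine nitrogen in a ring and so carries 2-methylphenyl in place of 4-methoxyphenyl on a saturated chain carbon bound to an amine nitrogen in a ring. Among the compounds with values here, only one measured step bears on it: a 1.3-fold lower number from compound 1 to compound 2 (0.13 log units; within the scatter) when methoxy replaced hydrogen on an aromatic carbon. That step stayed within the scatter. Within the data shown here, no compound measured so far carries the methyl group, so that part of the change is untested. No step beyond the scatter is therefore expected in this assay and no direction can be favoured. The expected step is a 1.0-fold lower number from compound 2 to compound 3 (0.01 log units; within the scatter) and remains an estimate. Compound 3 is expected at 60000 nM with an estimated range from 30000 nM to 120000 nM.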

Compound 3, half-maximal inhibitory concentration: 65300 nM
Compound 3: middle estimate off by 1.1-fold (0.04 log units), on the low side; the range from low to high includes it.
By their numbers in this assay, from the lowest: compounds 2, 3 and 1 (each within the scatter of the next).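

In this assay the exchange of 4-methoxyphenyl for 2-methylphenyl gives a 1.1-fold higher number from compound 2 to compound 3 (0.03 log units; within the scatter) and so removes the hydrogen-bond acceptor of the methoxy group without a step beyond the scatter. The methyl group, read on its own, gives a 1.3-fold lower number from compound 1 to compound 3 (0.10 log units; within the scatter) and thus adds a second substituent that leaves the number within the scatter, so that benzyl, 4-methoxybenzyl and 2-methylbenzyl cannot be told apart at this position. No supporting measurement is available to explain this result.

The compounds shown leave open whether any change at this position can produce a step beyond the scatter, for example a carboxylic acid or an amine on the aromatic ring. They also leave open whether a longer chain between that ring and the ring nitrogen would do so.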